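Trimethoxyphenyl for chlorophenyl on the shared core

The source may hold more compounds than are shown below. What is called first, only, known or untested is meant among the compounds shown, and "the series" means these compounds.

Measured so far:
compound 1, `COc1cc(/C=C/C(=O)c2cccc(-n3cc(-c4ccc(Cl)cc4)[nH]c3=O)c2)cc(OC)c1OC`, in a functional assay on NCI-H226 cells (Homo sapiens) for inhibition (a higher number here means a weaker inhibitor of growth, a lower number a stronger inhibitor of growth), compound 1 gives "not active" (no number reported), with no number
compound 2, `O=C(/C=C/c1cccc(O)c1)c1cccc(-n2cc(-c3ccccc3)[nH]c2=O)c1`, in this assay compound 2 gives 24800 nM
compound 3, `COc1ccc(-c2cn(-c3cccc(C(=O)/C=C/c4ccc(O)c(OC)c4)c3)c(=O)[nH]2)cc1`, in this assay compound 3 gives 4100 nM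

Compound 1 stands apart from the other two: in this assay it produced no value at all, only the statement that it does not inhibit growth. Within the data shown here, compounds 2 and 3 do give numbers, and compound 3 sits at the lower end of the pair, but no step between them is counted here, so only their two values can be compared as they stand.

Compound 4, `COc1cc(/C=C/C(=O)c2cccc(-n3cc(-c4cc(OC)c(OC)c(OC)c4)[nH]c3=O)c2)cc(OC)c1OC`, is obtained from compound 1 by the change (3,4,5-trimethoxyphenyl in place of 4-chlorophenyl on an aromatic carbon). Among the measured compounds shown here, no measured pair follows this change, so its size is open. Because compound 1 gives "not active" (no number reported) in this assay, the starting point is undefined; the expectation is that compound 4 will, at best, land in the weak range where compound 2 and compound 3 lie, and may again return no number. For compound 4 the estimated value in this assay is 20000 nM, with a range from 4000 nM to 80000 nM.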

Compound 4, concentration for 50% growth inhibition: 14400 nM
Beside the measured number, compound 4's estimate is 1.4-fold (0.14 log units) above it; the range from low to high includes it.
By their numbers in this assay, from the lowest: compound 3; then compounds 4 and 2 (each within the scatter of the next).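

In this assay, among these compounds, compound 4 gives 14400 nM while compound 1 gives "not active" (no number reported) so no step between the two can be read. The compounds shown leave open how much 3,4,5-trimethoxyphenyl in place of 4-chlorophenyl changes growth inhibition on the shared core. No measured evidence bears on this result.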